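Anilide in place of the 3-methoxybenzyl amide

The source may report more compounds than this note shows. Statements on the series, on what has been measured and on what is new or still open speak of the compounds shown alone.

Two compounds on the shared core have a reading in a functional assay on MDA-MB-435 cells (Homo sapiens) for cytotoxicity, read by MTT assay, with a stated time of 72 h; a lower number here means a stronger inhibitor, a higher number a weaker inhibitor. Compound 1 `O=C(NCc1ccc(F)cc1)c1nc(Br)c2cccnc2c1NCc1ccc(F)cc1` reaches only the limit of this assay, > 20000 nM. Compound 2 `COc1cccc(CNC(=O)c2nc(Br)c3cccnc3c2N[C@H]2CC[C@H](N)CC2)c1` gives 7000 nM in this assay. For the measured compounds named here, that is the only number in the set, since the other value sits at the limit of > 20000 nM in this assay, at which 1 of the 2 values shown sits, so compound 2 stands alone as the one compound with a measured concentration.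

Compound 3 `N[C@H]1CC[C@H](Nc2c(C(=O)Nc3ccccc3)nc(Br)c3cccnc23)CC1` differs from compound 2 in one place: phenyl in place of 3-methoxybenzyl on an amide-type nitrogen. Going by the values given here, no pair of measured compounds shows this change, so its size is unknown from the data. The expectation is a step from compound 2 to compound 3 that is small and, if anything, toward a weaker inhibitor, with a real chance that only a limit is returned; the expected step is a 1.7-fold higher number from compound 2 to compound 3 (0.23 log units; within the scatter). For compound 3 in this assay the estimate is 12000 nM, within a range of 3500 nM to 40000 nM.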

Compound 3, half-maximal inhibitory concentration: 1000 nM
Compound 3: middle estimate off by 12-fold (1.08 log units), on the high side; measured number below the stated range.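

For the compounds shown here, this is the first readable step at the amide-type nitrogen: in this assay, phenyl in place of 3-methoxybenzyl gives a 7.0-fold lower number from compound 2 to compound 3 (0.85 log units; beyond the scatter). The amide substituent therefore changes the read-out on the shared core, and the 3-methoxybenzyl group is not needed for the activity of compound 3, which carries the directly attached phenyl ring and has fewer heavy atoms in this place. No measured property available here accounts for the step.

Going by these compounds alone, the change removes the methoxy group and the benzyl methylene together, so the single step does not separate their contributions. Unsubstituted benzyl or 3-methoxyphenyl on this nitrogen would separate them, and an amine or a carboxylic acid on the phenyl ring of compound 3 remains an open variation.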